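Aryl swap at the saturated ring carbon: compound 4

The source may report more compounds than this note shows. Statements on the series, on what has been measured and on what is new or still open speak of the compounds shown alone.

Values measured in a functional assay on thoracic aorta for inhibition of Voltage-gated L-type calcium channel (Rattus norvegicus); on this read-out higher numbers stand for weaker inhibition and lower numbers for stronger inhibition:
Compound 1 `CC1=NC(C)=C(C(=O)O)C(c2cccc(F)c2)/C1=C(\O)OC/C=C/c1ccccc1`: 20 nM
Compound 2 `CC1=NC(C)=C(C(=O)O)C(c2cccc(Cl)c2)/C1=C(\O)OC/C=C/c1ccccc1`: 20 nM
Compound 3 `CC1=NC(C)=C(C(=O)O)C(c2cccc(Br)c2)/C1=C(\O)OC/C=C/c1ccccc1`: 10 nM

On the numbers as read, compound 3 stands lowest of the three, yet every step to it stays within the scatter: a 2.0-fold lower number from compound 1 to compound 3 (0.30 log units; within the scatter), a 2.0-fold lower number from compound 2 to compound 3 (0.30 log units; within the scatter), and between the other two no change at the digits printed from compound 1 to compound 2 (within the scatter). The three halogen variants therefore cannot be ordered in this assay.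

Compound 4 `CC1=NC(C)=C(C(=O)O)C(c2ccsc2)/C1=C(\O)OC/C=C/c1ccccc1` differs from compound 3 by thiophen-3-yl in place of 3-bromophenyl on a saturated ring carbon. For the measured compounds named here, no measured step covers an exchange of this kind; the three known steps each trade one halogen for another on the same ring and all lie within the scatter, which shows that this assay tolerates variation among those three halogens at this position but gives no basis for a direction once the ring itself is replaced. The expected step is thus none beyond the scatter, set with a broad band to allow for the untested ring type: a 2.5-fold higher number from compound 3 to compound 4 (0.40 log units; beyond the scatter). Compound 4 is estimated at 25 nM, with a range from 6 nM to 120 nM.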

Compound 4, half-maximal inhibitory concentration: 44 nM
Compound 4: middle estimate off by 1.8-fold (0.25 log units), on the low side; the measured number falls inside the stated range.
By their numbers in this assay, from the lowest: compounds 3, 1 and 2 (each within the scatter of the next); then compound 4.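

In this assay, the aryl group on the saturated ring carbon proves to be a point where the number moves beyond the scatter, which the exchanges among the three halogens did not show. Thiophen-3-yl gives a higher number than each halogen-bearing phenyl group, with steps of similar or larger size: (a 4.4-fold higher number from compound 3 to compound 4 (0.64 log units; beyond the scatter)), (a 2.2-fold higher number from compound 2 to compound 4 (0.34 log units; beyond the scatter)) and (a 2.2-fold higher number from compound 1 to compound 4 (0.34 log units; beyond the scatter)). No available evidence bears on the origin of these steps.

Still open, on these data alone, is whether the steps follow from the five-membered sulfur-containing ring itself or from the absence of a halogen; a plain phenyl group on this carbon would separate the two. Also open, as far as these compounds go, is how an aryl group carrying a methoxy group or an amine would compare with these compounds.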